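A few compounds are considered here, and "the series" means these few. Any claim that something is new, unique, unknown or untested is made for them only; others in the source may bear on it.

Measured so far in an ADME assay on microsomes from liver (Rattus norvegicus) for metabolic stability, read by HPLC, with a stated time of 10 min, tested at 3 uM; on this read-out higher numbers stand for a more stable compound and lower numbers for a less stable compound:
- compound 1 `COc1nc(C)c(Nc2nc(Cl)cn([C@H](C)C3CC3)c2=O)cc1C`: 55%
- compound 2 `COC[C@@H](C)n1cc(Cl)nc(Nc2cc(C)c(OC)nc2C)c1=O`: 8%
- compound 3 `Cc1cc(Nc2nc(Cl)cn([C@H](C)C3CC3)c2=O)c(C)nc1OC(F)F`: 86%

Compound 3 holds the highest of the three numbers, with compound 1 nearest and compound 2 furthest. Compound 4 `COC[C@@H](C)n1cc(Cl)nc(Nc2cc(C)c(OC(F)F)nc2C)c1=O` differs from compound 3 in one place: methoxymethyl in place of cyclopropyl on a saturated chain carbon bound to an aromatic nitrogen and a saturated chain carbon. This is methoxymethyl in place of cyclopropyl on a saturated chain carbon bound to an aromatic nitrogen and a saturated chain carbon.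

The same change has been measured once, as a number 47 percentage points lower from compound 1 to compound 2 (beyond the scatter), a large step beyond the scatter. The other measured step, a number 31 percentage points higher from compound 1 to compound 3 (beyond the scatter), replaces methyl with difluoromethyl on an oxygen on an aromatic ring, and compound 4 keeps that difluoromethyl. For the measured compounds named here, no measured compound shows how the two changes combine, so a single precedent carries the expectation. A large fall in this assay is expected, with its size uncertain from this higher starting value. The estimated step is a number 46 percentage points lower from compound 3 to compound 4 (beyond the scatter). The estimate for compound 4 is 40%, with an expected range from 18% to 62%.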

Compound 4, percent of the compound remaining: 66%
The estimate for compound 4 lay 26 percentage points below the measured number; measured number above the stated range.
By their numbers in this assay, from the lowest: compound 2; then compound 1; then compound 4; then compound 3.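

In this assay, methoxymethyl in place of cyclopropyl now appears on a second core and keeps its direction, with a number 20 percentage points lower from compound 3 to compound 4 (beyond the scatter), but the size of the step depends on the group on the oxygen on an aromatic ring: the same change on two cores in this assay, a number 47 percentage points lower (beyond the scatter) from compound 1 to compound 2 and a number 20 percentage points lower (beyond the scatter) from compound 3 to compound 4, 27 percentage points apart, beyond the scatter of two such steps

Read the other way, difluoromethyl in place of methyl keeps its direction too, with a number 58 percentage points higher from compound 2 to compound 4 (beyond the scatter), and this step is larger with methoxymethyl present than with cyclopropyl: the same change on two cores in this assay, a number 31 percentage points higher (beyond the scatter) from compound 1 to compound 3 and a number 58 percentage points higher (beyond the scatter) from compound 2 to compound 4, 27 percentage points apart, beyond the scatter of two such steps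

The two changes therefore do not add independently on this read-out across these four compounds.

Going by these compounds, the four compounds form a single pair of pairs, so it remains open whether the same dependence holds for other groups on the saturated chain carbon, such as an amine or a longer ether chain. On these data alone, it is also open how trifluoromethyl on the same oxygen would behave with either cyclopropyl or methoxymethyl.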